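Taking the nitro group off compound 1

The compounds below may be only part of what the source reports. "The series", "measured", "known", "first", "only" and "open" are said of these compounds alone.

Values in a functional assay on BCG823 cells (Homo sapiens) for cytotoxicity, read by MTT assay; a lower number here means a stronger inhibitor, a higher number a weaker inhibitor:
- compound 1 `CC1(C)C2CCC1(C)C(OC(=O)/C=C/c1ccc(O)c(O)c1[N+](=O)[O-])C2`: 117000 nM
- compound 2 `O=C(/C=C/c1cc(O)c(O)c([N+](=O)[O-])c1)OCCc1ccccc1`: 22900 nM
- compound 3 `COc1cc(/C=C/C(=O)OCCc2ccccc2)cc([N+](=O)[O-])c1O`: > 300000 nM, a limit of the assay and not a number

Compound 1 has the higher of the two exact numbers, and compound 2 lies clearly below it. Compound 4 `CC1(C)C2CCC1(C)C(OC(=O)/C=C/c1ccc(O)c(O)c1)C2` differs from compound 1 by hydrogen in place of nitro on an aromatic carbon. Within the data shown here, no measured step makes this change. Among the measured compounds shown here, the only measured step is a different one, methyl in place of hydrogen on an oxygen on an aromatic ring, an at least 13-fold higher number from compound 2 to compound 3 (1.11 log units; beyond the scatter). It shows that one small change can matter greatly in this series, so a step beyond the scatter is possible. Compound 1 already sits high at 117000 nM, so a lower number seems the likelier direction, though this is uncertain. The expected step is a 2.0-fold lower number from compound 1 to compound 4 (0.29 log units; within the scatter). Compound 4 is estimated at 60000 nM, with an expected range from 15000 nM to 200000 nM.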

Compound 4, half-maximal inhibitory concentration: 101000 nM
Beside the measured number, compound 4's estimate is 1.7-fold (0.23 log units) below it; low and high end bracket the measured number.
By their numbers in this assay, from the lowest: compound 2; then compounds 4 and 1 (each within the scatter of the next). At a limit, above all of these: compound 3.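

In this assay replacing the nitro group with hydrogen gives a 1.2-fold lower number from compound 1 to compound 4 (0.06 log units; within the scatter) and so makes no measurable difference at this aromatic carbon, ortho to a hydroxy group. Among these compounds, the one earlier step showed that a small change can matter greatly, but this change, though it removes more atoms than adding a methyl does, does not. Nothing shown here explains this result.

An amine or a carboxylic acid on this same carbon remains untested among the compounds shown. Also open, going by these compounds, is whether taking the nitro group off compound 2 would matter as little.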